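Thiophene for hydroxyphenyl on the aminopyrimidine arm

The compounds below may be only part of what the source reports. "The series", "measured", "known", "first", "only" and "open" are said of these compounds alone.

Measured so far:
compound 1 `Cn1cc(/C=C2/C(=O)Nc3ccccc32)c2cc(Nc3nccc(-c4ccccc4)n3)ccc21`: 17300 nM
compound 2 `Cn1cc(/C=C2/C(=O)Nc3ccccc32)c2cc(Nc3nccc(-c4ccc(O)cc4)n3)ccc21`: 9270 nM

In a functional assay on PA-1 cells (Homo sapiens) for cytotoxicity, read by MTT assay, with a stated time of 48 h (on this read-out higher numbers stand for weaker inhibition and lower numbers for stronger inhibition), compound 2 gives the lowest of the two numbers, with compound 1 nearest; the gap a 1.9-fold lower number from compound 1 to compound 2 (0.27 log units; within the scatter) lies within the scatter, so the two compounds cannot be ordered on these data.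

Compound 3 `Cn1cc(/C=C2/C(=O)Nc3ccccc32)c2cc(Nc3nccc(-c4cccs4)n3)ccc21` differs from compound 2 by thiophen-2-yl in place of 4-hydroxyphenyl on an aromatic carbon. Among the compounds with values here, the only measured step, a 1.9-fold lower number from compound 1 to compound 2 (0.27 log units; within the scatter), concerns the same position and shows that adding or removing the hydroxy group moves the number by less than the scatter. Within the data shown here, exchanging the whole hydroxyphenyl for thiophen-2-yl is a larger change, and no measured pair covers it, but the one step that exists gives no reason to expect a shift beyond the scatter in either direction.

Compound 3 is therefore expected near the two measured values, estimated at 14000 nM with a range of 5000 nM to 40000 nM; the expected step from compound 2 is a 1.5-fold higher number from compound 2 to compound 3 (0.18 log units; within the scatter).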

Compound 3, half-maximal inhibitory concentration: 7940 nM
Compound 3: middle estimate off by 1.8-fold (0.25 log units), on the high side; the range from low to high includes it.
By their numbers in this assay, from the lowest: compounds 3, 2 and 1 (each within the scatter of the next, the first and the last beyond it).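

In this assay, thiophen-2-yl stands in for 4-hydroxyphenyl on this aromatic carbon with no readable change, a 1.2-fold lower number from compound 2 to compound 3 (0.07 log units; within the scatter), so a five-membered ring with sulfur and no hydrogen-bond donor is accommodated here without leaving the scatter. Against the plain phenyl, the same group gives the first step in the series that clears the scatter, a 2.2-fold lower number from compound 1 to compound 3 (0.34 log units; beyond the scatter), though the step is modest and compound 2 lies within the scatter of both neighbours. Nothing at hand bears on the cause of either step.

Going by these compounds, whether an amine such as morpholin-4-yl, a carboxylic acid or a furan-2-yl ring on this carbon would move the number further remains open. Also open, on these data alone, is whether the modest step from phenyl to thiophen-2-yl holds on other cell lines.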